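Shortening a linker on a nucleotide-based probe

The source may report more compounds than this note shows. Statements on the series, on what has been measured and on what is new or still open speak of the compounds shown alone.

The study asks how well nucleotide triphosphate analogues carrying an iodoacetamide-tipped chain block hexokinase-3. In an assay on isolated protein for inhibition of hexokinase-3 (Rattus norvegicus), with a stated time of 6 h, tested at 10 mM (a higher number here means more inhibition at the concentration tested (going by the name of the read-out), a lower number less inhibition), compound 1 `O=C(CI)NCCCCC(=O)NCCCCCCNc1ncnc2c1ncn2[C@@H]1O[C@H](COP(=O)(O)OP(=O)(O)OP(=O)(O)O)[C@@H](O)[C@H]1O` gives 0%, and compound 2 `Nc1ncnc2c1nc(NCCCCNC(=O)CI)n2[C@@H]1O[C@H](COP(=O)(O)OP(=O)(O)OP(=O)(O)O)[C@@H](O)[C@H]1O` gives 0% in this assay, so compound 1 stands level with compound 2 at the digits shown, within the scatter, and neither shows any inhibition at the tested concentration.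

Compound 3 `O=C(I)NCC(=O)NCCCCCCNc1ncnc2c1ncn2[C@@H]1O[C@H](COP(=O)(O)OP(=O)(O)OP(=O)(O)O)[C@@H](O)[C@H]1O` has not yet been measured. It differs from compound 1 as follows: a group of 4 heavy atoms (1 carbon, 1 nitrogen, 1 oxygen, 1 iodine; no ring) in place of a group of 8 heavy atoms (5 carbon, 1 nitrogen, 1 oxygen, 1 iodine; no ring), on a saturated chain carbon bound to a carbonyl carbon. For the measured compounds named here, no two measured compounds differ in just one place, so there is no step on which to rest a forecast; the only guide is that both measured compounds sit at the same level. The step expected from compound 1 to compound 3 is no change at the digits printed from compound 1 to compound 3 (within the scatter), no change beyond the scatter, in either direction. Compound 3 is therefore estimated to give 0% in this assay, with a range from 0% to 12%.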

Compound 3, a percentage reported as inhibition, at one concentration (the size of the read-out at that concentration, not a potency): 0%
Compound 3: middle estimate and measured number agree at the digits printed, within the range that was stated.
By their numbers in this assay, from the lowest: compounds 1, 2 and 3 (each within the scatter of the next).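

In this assay, for the compounds shown here, putting the group of 4 heavy atoms in place of the 3-(((iodomethyl)carbonyl)amino)propyl group, on a saturated chain carbon bound to a carbonyl carbon, gives no change at the digits printed from compound 1 to compound 3 (within the scatter), the first step here in which only one place changes. Removing this much of the chain therefore brings out no inhibition at the concentration tested, but with no inhibition on either side of the step, it cannot show whether the size of this group would matter in a compound that does inhibit. No measurement is available that would explain this result.

On these data alone, whether a longer chain, an amine or a carboxylic acid at this place would give any inhibition remains open. So does whether any change to the shared core would produce a reading above zero, against which this position could be properly judged.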